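Removing a methylthiophene from a nitrochromene bis-amide

The source may report more compounds than this note shows. Statements on the series, on what has been measured and on what is new or still open speak of the compounds shown alone.

Three compounds share a core built from the structure of compound 1, `CCOc1cc(NC(=O)CCCCC(=O)Nc2cc(-c3ccc(C)s3)ccc2N)cc2c1OCC([N+](=O)[O-])=C2`, and were tested in a functional assay on A549 cells (Homo sapiens) for antiproliferative activity, read by MTT assay, with a stated time of 48 h (on this read-out lower numbers stand for stronger inhibition of growth and higher numbers for weaker inhibition of growth), where compound 1 gives 13800 nM. Compound 2, `CCOc1cc(NC(=O)CCCCC(=O)Nc2ccccc2N)cc2c1OCC([N+](=O)[O-])=C2`, gives 9630 nM. The change hydrogen in place of 5-methylthiophen-2-yl on an aromatic carbon made a 1.4-fold lower number from compound 1 to compound 2 (0.16 log units; within the scatter). Compound 3, `CCOc1cc(NC(=O)CCCCCC(=O)Nc2cc(-c3ccc(C)s3)ccc2N)cc2c1OCC([N+](=O)[O-])=C2`, gives 5070 nM; how its core differs from the core of compound 1 is not broken down here. Compound 4, `CCOc1cc(NC(=O)CCCCCC(=O)Nc2ccccc2N)cc2c1OCC([N+](=O)[O-])=C2`, has not yet been measured; it differs from compound 3 by hydrogen in place of 5-methylthiophen-2-yl on an aromatic carbon, the same change as from compound 1 to compound 2, at the same place. Because that earlier step was a 1.4-fold lower number from compound 1 to compound 2 (0.16 log units; within the scatter), the step of a 1.4-fold lower number from compound 3 to compound 4 (0.15 log units; within the scatter) is expected to be similar. Compound 4 is therefore expected to give about 3600 nM, between 1500 nM and 9000 nM.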

Compound 4, concentration for 50% growth inhibition: 12200 nM
Compound 4: middle estimate off by 3.4-fold (0.53 log units), on the low side; the measured number lies above the stated range.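

In this assay, replacing 5-methylthiophen-2-yl with hydrogen does not give the same result on both cores, so the earlier step is a poor guide here: the same change on two cores in this assay, a 1.4-fold lower number (0.16 log units; within the scatter) from compound 1 to compound 2 and a 2.4-fold higher number (0.38 log units; beyond the scatter) from compound 3 to compound 4, 3.4-fold (0.54 log units) apart, beyond the scatter of two such steps On the core of compound 3, the change gives a 2.4-fold higher number from compound 3 to compound 4 (0.38 log units; beyond the scatter), whereas without the 5-methylthiophen-2-yl group the two chain lengths stay close, with a 1.3-fold higher number from compound 2 to compound 4 (0.10 log units; within the scatter). These two pairs show that the change did not transfer in this series, but they do not explain the mismatch or set a general rule.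

The compounds shown leave open how a still longer chain would behave. They also leave open whether a phenyl group in place of 5-methylthiophen-2-yl would follow compound 1 or compound 3.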